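Return to an aryl substituent on the ring nitrogen

The source may hold more compounds than are shown below. What is called first, only, known or untested is meant among the compounds shown, and "the series" means these compounds.

Going by the values given here, compound 2 `CCCn1c(=O)[nH]c2nc(-c3ccc(S(=O)(=O)N4CCN(C(C)c5ccccc5)CC4)cc3)[nH]c2c1=O` gives 8.34 nM in an assay on CHO cells for displacement of a labelled ligand from adenosine receptor A2b (Homo sapiens), read by scintillation counting, with a stated time of 75 min, in the presence of a further agent that is not named here (on this read-out higher numbers stand for weaker inhibition and lower numbers for stronger inhibition), and holds the highest of the two numbers so far; its only neighbour, compound 1 `CCCn1c(=O)[nH]c2nc(-c3ccc(S(=O)(=O)N4CCN(c5ccccc5F)CC4)cc3)[nH]c2c1=O`, gives 3.22 nM in this assay. Compound 3 `CCCn1c(=O)[nH]c2nc(-c3ccc(S(=O)(=O)N4CCN(c5ccc(I)cc5)CC4)cc3)[nH]c2c1=O` differs from compound 2 by 4-iodophenyl in place of 1-phenylethyl on an amine nitrogen in a ring. Among the compounds with values here, one measured step bears on this change: a 2.6-fold higher number from compound 1 to compound 2 (0.41 log units; beyond the scatter), where an aryl group on that nitrogen gave way to a 1-phenylethyl. Compound 3 reverses that kind of change, putting an aryl group back on the ring nitrogen, though with 4-iodophenyl rather than 2-fluorophenyl, so the comparison is indirect. The expected result is a modest step down, roughly the size of the step seen between compound 1 and compound 2, given as a 2.1-fold lower number from compound 2 to compound 3 (0.32 log units; beyond the scatter). Compound 3 is therefore estimated at 4 nM in this assay, with a range of 1.3 nM to 12 nM.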

Compound 3, inhibition constant: 0.159 nM
Beside the measured number, compound 3's estimate is 25-fold (1.40 log units) above it, outside the stated range (below it).
By their numbers in this assay, from the lowest: compound 3; then compound 1; then compound 2.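

The group on the amine nitrogen in the ring carries far more weight in this assay than compounds 1 and 2 alone indicated, with a 52-fold lower number from compound 2 to compound 3 (1.72 log units; beyond the scatter) in place of the modest earlier step. The presence of an aryl group there does not settle the value, as a 20-fold lower number from compound 1 to compound 3 (1.31 log units; beyond the scatter) separates two aryl-bearing compounds on the same core. The choice of aryl substituent therefore matters at this position at least as much as the change from 1-phenylethyl to an aryl group, though no supporting data explain the size of either step.

Compounds 1 and 3 differ in both the halogen and its place on the phenyl ring, so the contribution of each remains unresolved. Unsubstituted phenyl, 2-iodophenyl and 4-fluorophenyl would separate the two, and 4-chlorophenyl or 4-bromophenyl would show whether the large step is specific to iodine.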